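The source may hold more compounds than are shown below. What is called first, only, known or untested is meant among the compounds shown, and "the series" means these compounds.

For the measured compounds named here, compound 1 `O=C(CN1CCN(S(=O)(=O)c2ccccc2F)CC1)Nc1ccccc1F` gives 99800 nM in an in vitro assay on HEK ts201 cells for negative allosteric modulation of Neuronal acetylcholine receptor; alpha3/beta4 (Homo sapiens), read by fluorescence and calcium flux, with a stated time of 1.5 s (a higher number here means a weaker inhibitor, a lower number a stronger inhibitor), the highest of the two numbers measured so far. Compound 2 `O=C(CN1CCN(S(=O)(=O)c2cccnc2)CC1)Nc1ccccc1F` gives 49600 nM in this assay, and the step of a 2.0-fold lower number from compound 1 to compound 2 (0.30 log units; within the scatter) comes from a change on the sulfonyl sulfur. Compound 3 `COc1ccc(NC(=O)CN2CCN(S(=O)(=O)c3ccccc3F)CC2)cc1` differs from compound 1 by 4-methoxyphenyl in place of 2-fluorophenyl on an amide-type nitrogen. Going by the values given here, no measured step touches the amide-type nitrogen, so none bears directly on this change, and the only step known, a 2.0-fold lower number from compound 1 to compound 2 (0.30 log units; within the scatter), stayed within the scatter. Compound 3 is therefore expected to show no step beyond the scatter, a 1.0-fold higher number from compound 1 to compound 3 (0.00 log units; within the scatter). The estimate for compound 3 in this assay is 100000 nM, with a range from 30000 nM to 300000 nM.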

Compound 3, half-maximal inhibitory concentration: 19100 nM
For compound 3 the middle estimate is 5.2-fold (0.72 log units) above the measured one; measured number below the stated range.
By their numbers in this assay, from the lowest: compound 3; then compounds 2 and 1 (each within the scatter of the next).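

On the amide-type nitrogen, 4-methoxyphenyl in place of 2-fluorophenyl gives a 5.2-fold lower number from compound 1 to compound 3 (0.72 log units; beyond the scatter) in this assay. For the compounds shown here, this is the first step beyond the scatter, whereas the one earlier step, on the sulfonyl sulfur, stayed within it. Nothing measured here accounts for the change.

The compounds shown do not separate the gain of the methoxy group from the loss of fluorine, and an unsubstituted phenyl or a 4-aminophenyl at this nitrogen remains untested here. From the compounds shown here alone, whether 4-methoxyphenyl combines with pyridin-3-yl on the sulfonyl sulfur also stays open.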